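Isopropyl to neopentyl on the shared core

This account rests on a few compounds, and the source may have more. Where it says the series, first, only, none or still open, it means among the compounds named here.

In a physicochemical assay for solubility, in phosphate buffer, with a stated time of 18 h, at pH 7.4 (on this read-out lower numbers stand for lower solubility and higher numbers for higher solubility), compound 1 `COc1cc2ncnc(-n3nc(-c4ccccn4)nc3N)c2cc1OCCCNC(=O)OC(C)(C)C` gives 2000 nM and compound 2 `COc1cc2ncnc(-n3nc(-c4ccccn4)nc3N)c2cc1OCCCNC(=O)OC(C)C` gives 18000 nM, so compound 2 holds the highest of the two numbers. Compound 3 `COc1cc2ncnc(-n3nc(-c4ccccn4)nc3N)c2cc1OCCCNC(=O)OCC(C)(C)C` remains unmeasured. It carries neopentyl in place of isopropyl on an oxygen next to a carbonyl group.

Within the data shown here, one measured step bears on this change: a 9.0-fold higher number from compound 1 to compound 2 (0.95 log units; beyond the scatter), with hydrogen in place of methyl. Read in reverse, that step adds a methyl and lowers the number. Compound 3 also gains carbon relative to compound 2, so a fall of similar size is expected in this assay. This rests on a single pair, and neopentyl is not the group of compound 1, so the expectation is loose. The expected change is a 9.0-fold lower number from compound 2 to compound 3 (0.95 log units; beyond the scatter). For compound 3 the estimated value is 2000 nM, with an expected range of 500 nM to 8000 nM.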

Compound 3, solubility: 200 nM
Compound 3: the middle estimate sits 10-fold (1.00 log units) above what was measured; measured number outside the range, below it.
By their numbers in this assay, from the lowest: compound 3; then compound 1; then compound 2.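

In this assay, neopentyl in place of isopropyl on an oxygen next to a carbonyl group gives a 90-fold lower number from compound 2 to compound 3 (1.95 log units; beyond the scatter), and neopentyl in place of tert-butyl gives a 10-fold lower number from compound 1 to compound 3 (1.00 log units; beyond the scatter). The number at this position therefore falls in the order isopropyl, tert-butyl, neopentyl, with no compound shown going against that order, and it does not level off at tert-butyl as the earlier pair alone might have allowed. No measurement available here accounts for these differences.

From the compounds shown here alone, all three groups at this position are saturated carbon groups, so the effect of an amine, a carboxylic acid or an ether-bearing chain in their place remains open. Also open, going by these compounds, is whether a longer straight chain or a cyclopropyl group would follow the same order.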